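A few compounds are considered here, and "the series" means these few. Any claim that something is new, unique, unknown or untested is made for them only; others in the source may bear on it.

Compound 1 `COc1ccccc1C(=O)Nc1nnc(SCC(=O)Nc2ccc(Br)cn2)s1` and compound 2 `COc1ccccc1C(=O)Nc1nnc(SCC(=O)Nc2ccc(Cl)cn2)s1` share one core; compound 3 `O=C(CCl)Nc1ccc(SCC(=O)Nc2ccc(Cl)cn2)cc1` and the unmeasured compound 4 `O=C(CCl)Nc1ccc(SCC(=O)Nc2ccc(Br)cn2)cc1` share another. In a functional assay on A875 cells (Homo sapiens) for antiproliferative activity, read by MTT assay, with a stated time of 48 h (on this read-out lower numbers stand for stronger inhibition and higher numbers for weaker inhibition), compound 1 gives only a limit of the assay, > 80000 nM. Compound 2 likewise gives only a limit in this assay, > 80000 nM. The step that the two limits leave unreadable from compound 2 to compound 1, the change (bromo in place of chloro on an aromatic carbon), is unreadable because both ends sit at the limit of > 80000 nM in this assay, at which 2 of the 3 values shown sit. How the core of compound 3 differs from that of compound 2 is not broken down here. In this assay compound 3 gives 98 nM. Within the data shown here, the change bromo in place of chloro on an aromatic carbon is the same change as the one from compound 2 to compound 1, at the same place. The earlier step gives no size to lean on. The step expected here is small, a 1.0-fold higher number from compound 3 to compound 4 (0.01 log units; within the scatter), resting on compound 3 at 98 nM and on one heavy atom replacing one. Compound 4 is thus expected at about 100 nM in this assay.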

Compound 4, half-maximal inhibitory concentration: 290 nM
Compound 4: the middle estimate sits 2.9-fold (0.46 log units) below what was measured; measured number outside the range, above it.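

In this assay, the change from 5-chloropyridin-2-yl to 5-bromopyridin-2-yl gives a 3.0-fold higher number from compound 3 to compound 4 (0.47 log units; beyond the scatter), so on this core the bromo compound is modestly weaker than the chloro compound. Whether the step carries over from the other core cannot be said, because compound 1 and compound 2 each give only a limit and not a number: the limit of > 80000 nM in this assay, at which 2 of the 4 values shown sit. The series therefore offers one readable step on one core, which measures no transfer between cores.

Still open, from the compounds shown here alone, is how a fluoro, a methyl or a nitrile would read at the same place on the core of compound 3. Also open, going by these compounds, is whether the step from chloro to bromo keeps its size on a third core.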